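The source may report more compounds than this note shows. Statements on the series, on what has been measured and on what is new or still open speak of the compounds shown alone.

In a functional assay on MCF7 cells (Homo sapiens) for cytotoxicity, read by MTT assay (a lower number here means a stronger inhibitor, a higher number a weaker inhibitor), three compounds sharing one core have been tested so far. Compound 2 (`COC(=O)C[C@H]1C[C@H](O)[C@@H](C)[C@@H](c2ccc(OC)cc2)N1`) gives 5100 nM and holds the lower of the two numbers available. Compound 3 (`COC(=O)C[C@H]1C[C@H](O)[C@@H](C)[C@@H](c2ccc(F)cc2)N1`) gives 18200 nM and compound 1 (`COC(=O)C[C@H]1C[C@H](O)[C@@H](C)[C@@H](c2ccc(C)cc2)N1`) is reported as "not active" (no number reported) without a number.

Compound 4 (`COc1ccc([C@H]2N[C@@H](CCO)C[C@H](O)[C@H]2C)cc1`) departs from compound 2 in one place: hydroxymethyl in place of methoxycarbonyl on a saturated chain carbon bound to a saturated ring carbon. Going by the values given here, no measured step touches that chain. Among the compounds with values here, the only measured step, fluoro in place of methoxy on an aromatic carbon, shows a 3.6-fold higher number from compound 2 to compound 3 (0.55 log units; beyond the scatter) and counts as modest, so it offers only a rough guide to size.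

Compound 2 at 5100 nM already sits at the low end, and compound 1 at "not active" (no number reported) shows that a close relative can give no number at all, so a modest move toward a higher number is expected. The estimated change is a 2.4-fold higher number from compound 2 to compound 4 (0.37 log units; beyond the scatter) in size. For compound 4 the expected value is 12000 nM with an estimated range from 4000 nM to 35000 nM on repeated measurement.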

Compound 4, half-maximal inhibitory concentration: 13700 nM
For compound 4 the middle estimate is 1.1-fold (0.06 log units) below the measured one; the range from low to high includes it.
By their numbers in this assay, from the lowest: compound 2; then compounds 4 and 3 (each within the scatter of the next).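

In this assay, this first change on the chain gives a 2.7-fold higher number from compound 2 to compound 4 (0.43 log units; beyond the scatter), so replacing methoxycarbonyl with hydroxymethyl moves the number modestly toward weaker inhibition. The step also shows that, at least for this pair, methoxycarbonyl is not required for a measurable number, since compound 4 still gives 13700 nM with 2-hydroxyethyl in place of (methoxycarbonyl)methyl. Nothing available explains the size or direction of this step.

The compounds shown leave open how a carboxylic acid, an amine or a longer chain would read at this place on a saturated chain carbon bound to a saturated ring carbon. They also leave open whether any group there could bring the number below that of compound 2.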